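Carbonate Acid in Place of the Amino Ester Chain

The source may report more compounds than this note shows. Statements on the series, on what has been measured and on what is new or still open speak of the compounds shown alone.

Compound 1 `CCCCOC(=O)OCC1OC(n2cc(C)c(=O)[nH]c2=O)CC1N=[N+]=[N-]` reaches only the limit > 50000 nM in a functional assay on MT4 cells (Homo sapiens) for cytotoxicity; a lower number here means that less compound is tolerated, a higher number that more compound is tolerated. Compound 2 `Cc1cn(C2CC(N=[N+]=[N-])C(COC(=O)CCCC(=O)O)O2)c(=O)[nH]c1=O` likewise gives only the limit > 50000 nM in this assay. Compound 3 `Cc1cn(C2CC(N=[N+]=[N-])C(COC(=O)CCCN)O2)c(=O)[nH]c1=O` also stands at the limit > 50000 nM in this assay, so every value shown sits together at the limit of > 50000 nM in this assay, at which 3 of the 3 values shown sit. The steps a step that the two limits leave unreadable from compound 1 to compound 2, a step that the two limits leave unreadable from compound 1 to compound 3 and a step that the two limits leave unreadable from compound 2 to compound 3 are consequently not readable. Compound 4 `Cc1cn(C2CC(N=[N+]=[N-])C(COC(=O)OCCCC(=O)O)O2)c(=O)[nH]c1=O` differs from compound 3 by 3-carboxypropoxy in place of 3-aminopropyl on a carbonyl carbon. Within the data shown here, no measured step gives a readable size for this kind of change, so nothing beyond the scatter is expected in this assay. The expected step is a step that the limit leaves unreadable from compound 3 to compound 4. Compound 4 is therefore estimated at 80000 nM, with a range from 30000 nM to 300000 nM, most likely again as a limit.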

Compound 4, half-maximal cytotoxic concentration: > 50000 nM
Compound 4 gave a limit, no number; the forecaster's own chance of this, stated with the estimate: 85%; the middle value lies beyond the limit too.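

Among these compounds, compound 4 gives only a limit in this assay, so no step to it from compound 1, compound 2 or compound 3 can be read: the limit of > 50000 nM in this assay, at which 4 of the 4 values shown sit. The compounds shown leave open whether these four differ in cytotoxicity at all.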